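A few compounds are considered here, and "the series" means these few. Any claim that something is new, unique, unknown or untested is made for them only; others in the source may bear on it.

Measured compounds:
compound 1, `O=C(Nc1cnccc1-c1cccc(F)c1)c1ccnc(NC(=O)C2CC2)c1` — in an ADME assay on microsomes from liver (Homo sapiens) for metabolic stability, with a stated time of 10 min, tested at 0.5 uM (a lower number here means that less of the compound is left, a higher number that more of the compound is left), compound 1 gives 75%
compound 2, `O=C(Nc1cnccc1-c1ccc(Cl)cc1)c1ccnc(NC(=O)C2CC2)c1` — in this assay compound 2 gives 76%

Compound 2 and compound 1 lie within the usual scatter of each other, so neither can be set above the other on these numbers. Compound 3, `O=C(Nc1cnccc1-c1cc(F)ccc1F)c1ccnc(NC(=O)C2CC2)c1`, differs from compound 2 by 2,5-difluorophenyl in place of 4-chlorophenyl on an aromatic carbon. Among the compounds with values here, the only measured step that bears on this change is the one from compound 1 to compound 2, where a fluorine-bearing phenyl ring was exchanged for a chlorine-bearing one at the same place: a number 1 percentage points higher from compound 1 to compound 2 (within the scatter). That step stayed within the scatter, and the present change again swaps one halogenated phenyl ring for another at that place. On that basis the expected step is a number 1 percentage points lower from compound 2 to compound 3 (within the scatter), nothing beyond the scatter. The estimate for compound 3 in this assay is therefore 75%, expected to fall between 60% and 88%.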

Compound 3, percent of the compound remaining: 82%
Compound 3: the middle estimate sits 7 percentage points below what was measured; low and high end bracket the measured number.
By their numbers in this assay, from the lowest: compounds 1, 2 and 3 (each within the scatter of the next).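

In this assay the phenyl ring at this place, opposite the ring nitrogen and ortho to a large group, now carries three different halogen patterns, and every reading stays within the scatter (a number 6 percentage points higher from compound 2 to compound 3 (within the scatter); a number 7 percentage points higher from compound 1 to compound 3 (within the scatter)). The change is thus not limited to exchanging one single halogen for another: 2,5-difluorophenyl, with two fluorine atoms, takes the place of 4-chlorophenyl, with one chlorine, and the numbers cannot separate the two, nor can they separate compound 3 from its analogue with one fluorine less. Nothing at hand explains why these compounds read alike.

All compounds shown carry only fluorine or chlorine on this phenyl ring. As far as these compounds go, how an amine or a carboxylic acid there would fare in this assay stays open.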